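Methoxy on the Fused Ring: Cytotoxicity Outlook

The compounds below may be only part of what the source reports. "The series", "measured", "known", "first", "only" and "open" are said of these compounds alone.

Compound 1 `COc1ccc(-c2ccc(C)n2-c2ccc(-c3nc4ccccc4s3)cc2)cc1` was tested in an ADME assay on MCF-10A cells (Homo sapiens) for cytotoxicity, read by MTT assay, with a stated time of 72 h (on this read-out lower numbers stand for stronger inhibition and higher numbers for weaker inhibition), where compound 1 gives 36300 nM. Compound 2 `Cc1ccc(-c2ccc([N+](=O)[O-])cc2)n1-c1ccc(-c2nc3ccccc3s2)cc1` gives 38800 nM in this assay. For the measured compounds named here, the single step so far, a 1.1-fold higher number from compound 1 to compound 2 (0.03 log units; within the scatter), places compound 2 alongside compound 1, the two numbers within the scatter of each other.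

Compound 3 `COc1ccc2nc(-c3ccc(-n4c(C)ccc4-c4ccc([N+](=O)[O-])cc4)cc3)sc2c1` carries one further change relative to compound 2: methoxy in place of hydrogen on an aromatic carbon. Going by the values given here, no measured step touches this place on the shared core; the only step available, a 1.1-fold higher number from compound 1 to compound 2 (0.03 log units; within the scatter), concerns a different ring and was itself within the scatter. The account therefore expects no step beyond the scatter for compound 3 in this assay, in either direction, with the expected step being a 1.0-fold lower number from compound 2 to compound 3 (0.01 log units; within the scatter). Compound 3 is estimated at 38000 nM, with a range from 15000 nM to 95000 nM.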

Compound 3, half-maximal inhibitory concentration: 34900 nM
The estimate for compound 3 lay 1.1-fold (0.04 log units) above the measured number, and the stated range covers the measured number.
By their numbers in this assay, from the lowest: compounds 3, 1 and 2 (each within the scatter of the next).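

In this assay, methoxy in place of hydrogen on an aromatic carbon of the fused system gives a 1.1-fold lower number from compound 2 to compound 3 (0.05 log units; within the scatter). For the compounds shown here, this is the first reading at this place on the shared core: the earlier step, a 1.1-fold higher number from compound 1 to compound 2 (0.03 log units; within the scatter), concerned a different ring, and the fused ring now shows that it can carry methoxy without a step beyond the scatter when nitro is present on the other ring. No measurement shown here offers an explanation for this outcome.

The compounds shown leave open whether an amine, a carboxylic acid or a longer chain at this place would give a step beyond the scatter. They also leave open whether methoxy at this place would read the same when the other ring carries methoxy rather than nitro.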